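The source may report more compounds than this note shows. Statements on the series, on what has been measured and on what is new or still open speak of the compounds shown alone.

The measured compounds:
compound 1, `CNC(=O)N1CCCc2ccc(NC(=O)c3cccc(-c4ccccc4)c3)cc21`, 1.39%
compound 2, `CNC(=O)N1CCCc2ccc(NC(=O)c3ccc(-c4cnn(S(C)(=O)=O)c4)cc3)cc21`, 40.2%
compound 3, `CNC(=O)N1CCCc2ccc(NC(=O)c3ccc(-c4cccnc4)cc3)cc21`, 92.1%

In a functional assay on MV4-11 cells (Homo sapiens) for antiproliferative activity, with a stated time of 6 days, tested at 6.25 uM (a higher number here means a stronger effect of the compound at the concentration tested, a lower number a weaker effect), compound 1 stands lowest of the three numbers: compound 2 sits above it beyond the scatter, and compound 3 lies furthest from it, also beyond the scatter. The unmeasured compound 4, `CNC(=O)N1CCCc2ccc(NC(=O)c3cccc(-c4cn[nH]c4)c3)cc21`, differs from compound 1 in one place: 1H-pyrazol-4-yl in place of phenyl on an aromatic carbon, on an aromatic carbon meta to a large group.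

For the measured compounds named here, no measured step swaps phenyl for 1H-pyrazol-4-yl. Going by the values given here, the only step, a number 51.9 percentage points higher from compound 2 to compound 3 (beyond the scatter), exchanges one heteroaryl for another and shows that the nature of this ring can move this assay by a large margin. Compound 2, which carries a substituted pyrazolyl, gives a middling number, and compound 1, with plain phenyl, gives almost none. Going by these compounds, compound 4 is therefore expected to rise from compound 1 by a number 33.6 percentage points higher from compound 1 to compound 4 (beyond the scatter), with wide uncertainty since the step is untested. The estimate for compound 4 is 35%, within 5% to 75%.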

Compound 4, a percentage reported as inhibition, at one concentration (the size of the read-out at that concentration, not a potency): 77.7%
Compound 4: middle estimate off by 42.7 percentage points, on the low side; the measured number lies above the stated range.
By their numbers in this assay, from the lowest: compound 1; then compound 2; then compound 4; then compound 3.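

On an aromatic carbon meta to a large group, exchanging phenyl for 1H-pyrazol-4-yl changes this assay by a large margin, with a number 76.3 percentage points higher from compound 1 to compound 4 (beyond the scatter). For the compounds shown here, the earlier step involved neither of these two rings, so this is the first sign that, at this position on the shared core, the choice between them can separate a nearly inactive compound from a strongly active one. The change replaces a six-membered carbon ring with a five-membered ring carrying two nitrogens, one hydrogen-bond donor and one acceptor, and no measurement available here connects the gain to any one of these differences.

Going by these compounds, it remains open whether 1-methyl-1H-pyrazol-4-yl, which has no ring hydrogen on nitrogen, would keep this number. Equally open, on these data alone, is how pyridin-3-yl would behave on this same carbon.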